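The source may hold more compounds than are shown below. What is called first, only, known or untested is meant among the compounds shown, and "the series" means these compounds.

Measured in a functional assay on HepG2 cells (Homo sapiens) for antiproliferative activity, read by MTT assay, with a stated time of 24 h (a higher number here means a weaker inhibitor, a lower number a stronger inhibitor), so far:
- Compound 1 `Sc1nnc(-c2ccc3c(c2)OCCO3)n1-c1ccccc1` gives 60000 nM
- Compound 2 `Cc1ccccc1CSc1nnc(-c2ccc3c(c2)OCCO3)n1-c1ccccc1` gives 20500 nM
- Compound 3 `Cc1ccc(CSc2nnc(-c3ccc4c(c3)OCCO4)n2-c2ccccc2)cc1` gives 56800 nM

Compound 3 is level with compound 1, as a 1.1-fold lower number from compound 1 to compound 3 (0.02 log units; within the scatter) shows, and a 2.8-fold higher number from compound 2 to compound 3 (0.44 log units; beyond the scatter) separates it from compound 2. Compound 4 `Brc1ccc(CSc2nnc(-c3ccc4c(c3)OCCO4)n2-c2ccccc2)cc1` has bromo in place of methyl on an aromatic carbon, para to a large group (bromo in place of methyl on an aromatic carbon). Among the measured compounds shown here, no measured step makes this exchange. The nearest evidence is a 2.9-fold lower number from compound 1 to compound 2 (0.47 log units; beyond the scatter) and the two steps above, which are modest at most. In this assay the expected change is therefore small and within the scatter, with a 1.3-fold lower number from compound 3 to compound 4 (0.10 log units; within the scatter) as the estimated step. For compound 4 the expected value is 45000 nM (estimated range 18000 nM to 100000 nM).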

Compound 4, half-maximal inhibitory concentration: 7940 nM
Beside the measured number, compound 4's estimate is 5.7-fold (0.75 log units) above it; the whole stated range lies above it.
By their numbers in this assay, from the lowest: compound 4; then compound 2; then compounds 3 and 1 (each within the scatter of the next).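

The position para to a large group proves sensitive after all: 4-methylbenzyl had sat level with hydrogen on the sulfur, yet bromo in place of methyl gives a 7.2-fold lower number from compound 3 to compound 4 (0.85 log units; beyond the scatter) and so separates the benzyl series from the parent, with a 7.6-fold lower number from compound 1 to compound 4 (0.88 log units; beyond the scatter) as the result. The 4-bromobenzyl group also outdoes the 2-methylbenzyl group, with a 2.6-fold lower number from compound 2 to compound 4 (0.41 log units; beyond the scatter) as the measure, so compound 4 has the lowest number of the four. Nothing available explains why this exchange counts for so much. As far as these compounds go, whether chloro, fluoro or methoxy on the same aromatic carbon would follow bromo or methyl remains open.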